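Methyl for nitro on the aryl ring of an imidazoline

A few compounds are considered here, and "the series" means these few. Any claim that something is new, unique, unknown or untested is made for them only; others in the source may bear on it.

Measured compounds:
compound 1, `CC(Oc1ccccc1-c1cccnc1)C1=NCCN1`, 1
compound 2, `CC(Oc1ccccc1-c1ccccc1[N+](=O)[O-])C1=NCCN1`, < 0.3

Of the compounds shown here, two have been measured in a functional assay on CHO cells for agonist activity at Alpha-2C adrenergic receptor (Homo sapiens); a higher number here means a larger maximal response, a lower number a smaller maximal response. Compound 1, `CC(Oc1ccccc1-c1cccnc1)C1=NCCN1`, gives 1. For compound 2, `CC(Oc1ccccc1-c1ccccc1[N+](=O)[O-])C1=NCCN1`, only a limit is known: < 0.3. That limit is where compound 2 stands, since (the limit of < 0.3 in this assay, at which 1 of the 2 values shown sits), so its value in this assay is bounded from above and not fixed.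

The step from compound 2 to compound 3, `Cc1ccccc1-c1ccccc1OC(C)C1=NCCN1`, is methyl in place of nitro on an aromatic carbon. Among the measured compounds shown here, no pair of measured compounds shows a step of this kind, so there is nothing to set its size. The estimated step a number at least 0.25 higher from compound 2 to compound 3 (beyond the scatter) is expected to move upward and beyond the scatter. Compound 3 is accordingly expected to give 0.55 in this assay, within a range from 0.15 to 0.95.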

Compound 3, intrinsic activity: the largest response reached, as a fraction of the reference agonist's: 0.45
The estimate for compound 3 lay 0.10 above the measured number, and the stated range covers the measured number.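

In this assay, methyl in place of nitro on an aromatic carbon, ortho to a large group, gives a number at least 0.15 higher from compound 2 to compound 3 (beyond the scatter), so this position can carry a clear response with a small carbon group on the ring. That step has only a lower bound, since the read-out for compound 2 is a limit and not a number: the limit of < 0.3 in this assay, at which 1 of the 3 values shown sits. The second comparison adds a ceiling to this picture, as 2-methylphenyl in place of pyridin-3-yl gives a number 0.55 lower from compound 1 to compound 3 (beyond the scatter), leaving the methyl compound well short of the full response of compound 1.

The compounds shown leave open how a methoxy group, an amine or a longer chain such as ethyl would read on the same aromatic carbon. They also leave open whether any such group would bring the response closer to that of compound 1.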